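The compounds below may be only part of what the source reports. "The series", "measured", "known", "first", "only" and "open" are said of these compounds alone.

Measured in a functional assay on KB cells (Homo sapiens) for antiproliferative activity, read by MTT assay, with a stated time of 72 h; a lower number here means a stronger inhibitor, a higher number a weaker inhibitor:
Compound 1 `CCOC(=O)c1cc(-c2cc(OC)c(OC)c(OC)c2)c(-c2cccc(Br)c2)s1`: > 100000 nM (a limit)
Compound 2 `CCOC(=O)c1cc(-c2cc(OC)c(OC)c(OC)c2)c(-c2ccc(OC)c(OCc3ccccc3)c2)s1`: > 100000 nM (a limit)
Compound 3 `COc1cc(-c2cc(C(=O)O)sc2-c2cccc(Br)c2)cc(OC)c1OC`: 32300 nM

Among these three, only compound 3 has a true number, 32300 nM. The other two results are limits, not numbers: the limit of > 100000 nM in this assay, at which 2 of the 3 values shown sit. Going by the values given here, the one measured step, an at least 3.0-fold lower number from compound 1 to compound 3 (0.49 log units; beyond the scatter), replaces ethyl with hydrogen and lies beyond the scatter.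

Compound 4 `COc1ccc(-c2sc(C(=O)O)cc2-c2cc(OC)c(OC)c(OC)c2)cc1O` keeps the carboxy group of compound 3 but changes the other side of the molecule: 3-hydroxy-4-methoxyphenyl in place of 3-bromophenyl on an aromatic carbon. Here, 3-hydroxy-4-methoxyphenyl takes the place of 3-bromophenyl on the aromatic carbon next to the ring sulfur. Among the compounds with values here, no measured step covers this kind of swap. Compound 1 and compound 2 differ at this same place, but both results are limits, so that pair gives no size.

The step of an at least 3.0-fold lower number from compound 1 to compound 3 (0.49 log units; beyond the scatter) is therefore the only yardstick, and it concerns a different part of the molecule. A modest move toward a lower number is expected, though this is a judgement based on the incoming group and is very uncertain. The expected change is a 4.0-fold lower number from compound 3 to compound 4 (0.61 log units; beyond the scatter). For compound 4 the estimated value is 8000 nM, with an expected range from 500 nM to 80000 nM.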

Compound 4, half-maximal inhibitory concentration: 11200 nM
Compound 4: the middle estimate sits 1.4-fold (0.15 log units) below what was measured; the measured number falls inside the stated range.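

With the carboxy group in place, the group on the aromatic carbon next to the ring sulfur now has a measured effect: in this assay, putting 3-hydroxy-4-methoxyphenyl in place of 3-bromophenyl gives a 2.9-fold lower number from compound 3 to compound 4 (0.46 log units; beyond the scatter). Going by these compounds alone, this is the first readable evidence that the number responds to a change at this position, and the step is modest rather than large. Compound 1 and compound 2 differ at the same place, but the step between them cannot be read because both results are limits: the limit of > 100000 nM in this assay, at which 2 of the 4 values shown sit.

This single pair gives the size of one swap and no general rule for the position, and since the bromine leaves as the hydroxy and methoxy groups enter, the shift cannot be assigned to any one of these changes. It also leaves open how the number would respond to a 3-amino-4-methoxyphenyl group at this position, with an amine in place of the hydroxy, or to a plain 4-methoxyphenyl group on the same core with the carboxy group kept.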